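The source may report more compounds than this note shows. Statements on the series, on what has been measured and on what is new or still open speak of the compounds shown alone.

Working notes on the series, read in a functional assay on HepG2 cells (Homo sapiens) for cytotoxicity, with a stated time of 72 h; a lower number here means that less compound is needed, a higher number that more compound is needed for the effect. Compound 1 `C=C[C@@](C)(/C=C/c1ccc(OC)cc1)CCC=C(C)C` gives > 52000 nM, which is a limit and not a number. Compound 2 `C=C[C@@](C)(/C=C/c1ccc(O)cc1)CCC(O)C(C)(C)O` gives > 52000 nM, again a limit. Compound 3 `C=C[C@@](C)(/C=C/c1ccc(O)cc1)CCC=O` gives > 52000 nM, so it too stands only at a limit, with no number to place it against the other two. The whole picture in this assay is the limit of > 52000 nM in this assay, at which 3 of the 3 values shown sit.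

The next change replaces formyl with 2-(ethoxycarbonyl)ethenyl on a saturated chain carbon, three bonds along the chain from two double-bonded chain carbons, and leads to compound 4 `C=C[C@@](C)(/C=C/c1ccc(O)cc1)CC/C=C/C(=O)OCC`: 2-(ethoxycarbonyl)ethenyl in place of formyl on a saturated chain carbon, three bonds along the chain from two double-bonded chain carbons.

Among the measured compounds shown here, only one measured step bears on this site, a step that the two limits leave unreadable from compound 2 to compound 3. It changes the same chain position, but it gives no size to carry forward, and no direction either. The expectation therefore rests on compound 3, whose > 52000 nM is a limit. No step beyond the usual scatter is expected in this assay, and no direction can be argued from these data. The expected step is a number no higher from compound 3 to compound 4 (the limit leaves the size open). For compound 4 the estimated value is 52000 nM, with an expected range of 25000 nM to 80000 nM, and another report as a limit is the likeliest outcome.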

Compound 4, half-maximal effective concentration: > 52000 nM
Compound 4 gave a limit, no number; the forecaster's own chance of this, stated with the estimate: 75%; the middle value lies on the limit itself.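

Among the compounds shown here, compound 4 stands only at a limit, as do compound 2 and compound 3, so no step to compound 4 can be read in this assay. The compounds shown leave open whether any group on this saturated chain carbon gives a readable number, and the whole picture remains a single limit: the limit of > 52000 nM in this assay, at which 4 of the 4 values shown sit.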